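Three hydroxyamide analogs and an unmeasured ether variant

A few compounds are considered here, and "the series" means these few. Any claim that something is new, unique, unknown or untested is made for them only; others in the source may bear on it.

The series comprises compound 1 `CC(C)(C)[C@@H](O)C(=O)N1N=CC[C@H]1C(=O)NCc1cc(Cl)ccc1-n1cnnn1`, compound 2 `O=C(NCc1cc(Cl)ccc1-n1cnnn1)[C@@H]1C[C@@H]2C[C@@H]2N1C(=O)[C@H](O)c1ccccc1F` and compound 3 `O=C(NCc1cc(Cl)ccc1-n1cnnn1)[C@@H]1[C@H]2C[C@H]2CN1C(=O)[C@H](O)Cn1cccn1`, all measured in a functional assay on a cell-free system (plasma, Homo sapiens), with a stated time of 3 min; a lower number here means a stronger inhibitor, a higher number a weaker inhibitor. Compound 1 gives 1400 nM, compound 2 gives 770 nM and compound 3 gives 1800 nM. Compound 2 has the lowest number of the three, yet compound 1 sits within the scatter of it; only compound 3 lies beyond. The unmeasured compound 4 `CC(C)(C)OC[C@@H](O)C(=O)N1[C@H](C(=O)NCc2cc(Cl)ccc2-n2cnnn2)C[C@@H]2C[C@@H]21` shares the core of compound 2 and differs from it in one place: (tert-butoxy)methyl in place of 2-fluorophenyl on a saturated chain carbon bound to a carbonyl carbon and an oxygen on a saturated carbon. Among the compounds with values here, no pair of measured compounds isolates this change, so its effect is not known. A small step toward a higher number is expected, a 1.6-fold higher number from compound 2 to compound 4 (0.19 log units; within the scatter), likely within the scatter. Compound 4 is estimated at 1200 nM, in the range 400 nM to 3500 nM.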

Compound 4, half-maximal inhibitory concentration: 500 nM
Estimate against measurement, compound 4: 2.4-fold (0.38 log units) above, and the stated range covers the measured number.
By their numbers in this assay, from the lowest: compounds 4, 2, 1 and 3 (each within the scatter of the next, the first and the last beyond it).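

In this assay, replacing 2-fluorophenyl with (tert-butoxy)methyl gives a 1.5-fold lower number from compound 2 to compound 4 (0.19 log units; within the scatter). At this saturated chain carbon, then, the six-membered aromatic ring can give way to a group with no ring without a shift beyond the scatter. Nothing available accounts for this result. The single step cannot show whether the oxygen of the (tert-butoxy)methyl group matters, as no matching all-carbon chain is among the compounds shown. On these data alone, how an amine or a carboxylic acid would read at this place also remains open.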